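A few compounds are considered here, and "the series" means these few. Any claim that something is new, unique, unknown or untested is made for them only; others in the source may bear on it.

Measured compounds:
compound 1, `CCN(Cc1ccc(C(=O)NO)cc1)C(=O)c1cc(Cl)c(O)cc1O`, 13200 nM
compound 2, `CCCCN(Cc1ccc(C(=O)NO)cc1)C(=O)c1cc(Cl)c(O)cc1O`, 66400 nM

In a functional assay on NCI-H1975 cells (Homo sapiens) for inhibition, with a stated time of 72 h (a higher number here means a weaker inhibitor of growth, a lower number a stronger inhibitor of growth), compound 1 stands lowest of the two numbers; its nearest neighbour is compound 2, reached by a 5.0-fold higher number from compound 1 to compound 2 (0.70 log units; beyond the scatter). That step alters the chain on the amide-type nitrogen, not the aromatic ring.

Compound 3, `CCN(Cc1ccc(C(=O)NO)cc1)C(=O)c1cc(C(C)C)c(O)cc1O`, differs from compound 1 by isopropyl in place of chloro on an aromatic carbon. Within the data shown here, no measured step touches this position, so the one step from compound 1 to compound 2 does not bear directly on it, and the size of the change must be judged without a precedent among the measured compounds. Without such a precedent, the expectation for compound 3 is a step within the scatter of compound 1, with a wide range to allow for either direction.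

Compound 3 is therefore estimated at about 13000 nM, between 4500 nM and 40000 nM. This estimate means an expected 1.0-fold lower number from compound 1 to compound 3 (0.01 log units; within the scatter).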

Compound 3, concentration for 50% growth inhibition: 7000 nM
Estimate against measurement, compound 3: 1.9-fold (0.27 log units) above, within the range that was stated.
By their numbers in this assay, from the lowest: compounds 3 and 1 (each within the scatter of the next); then compound 2.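

In this assay, the aromatic carbon ortho to a hydroxy group and para to a hydroxy group takes isopropyl in place of chloro with a 1.9-fold lower number from compound 1 to compound 3 (0.28 log units; within the scatter), so compound 3 and compound 1 cannot be told apart even though three carbon atoms replace one chlorine atom. Among these compounds, this is the first reading at this position, and this step stays within the scatter, whereas the chain change in a 5.0-fold higher number from compound 1 to compound 2 (0.70 log units; beyond the scatter) lies beyond it. Nothing available accounts for this tolerance.

The compounds shown leave open whether a much larger group, such as tert-butyl or phenyl, or a group of another kind, such as an amine or a carboxylic acid, would also stay within the scatter here. They also leave open whether isopropyl would behave the same way on a compound carrying the longer chain of compound 2.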